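The source may report more compounds than this note shows. Statements on the series, on what has been measured and on what is new or still open speak of the compounds shown alone.

For the measured compounds named here, compound 1 `O=C(N/N=C/c1ccccc1O)c1ccc(-c2ccc(F)cc2)o1` stands at the top of the three numbers so far. In a functional assay on Bel-7402 cells (Homo sapiens) for inhibition, read by sulforhodamine B assay, with a stated time of 48 h, tested at 10 uM (on this read-out higher numbers stand for more inhibition of growth at the one concentration tested and lower numbers for less inhibition of growth), compound 1 gives 40%. Compound 3 `Cc1cccc(/C=N/NC(=O)c2ccc(-c3ccccc3[N+](=O)[O-])o2)c1` comes nearest, with compound 3 giving 6.66% in this assay, a gap beyond the usual scatter. Compound 2 `O=C(N/N=C/c1ccccc1)c1ccc(-c2ccc(Cl)cc2)o1` lies furthest away, and in this assay compound 2 gives 2.28%, again beyond the scatter. Going by the values given here, both of these weaker compounds carry no hydroxy on the benzylidene ring, but each differs from compound 1 in more than one place, so no single step among the measured compounds isolates that group.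

Compound 4 `O=C(N/N=C/c1ccccc1Cl)c1ccc(-c2ccc(F)cc2)o1` is the untested member. It differs from compound 1 by chloro in place of hydroxy on an aromatic carbon. Among the compounds with values here, with no clean comparison available, the pattern that the two compounds lacking the hydroxy both sit low is the only guide, and it points downward. The step expected here, a number 25 percentage points lower from compound 1 to compound 4 (beyond the scatter), would be a loss beyond the scatter. Compound 4 is estimated at 15%, within a range from 0% to 40%.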

Compound 4, percent growth inhibition at one concentration: 4.81%
For compound 4 the middle estimate is 10.2 percentage points above the measured one; measured number inside the range.
By their numbers in this assay, from the lowest: compounds 2, 4 and 3 (each within the scatter of the next); then compound 1.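

For the compounds shown here, replacing hydroxy with chloro on an aromatic carbon, ortho to a large group, is the first single change that can be read here, and in this assay it gives a number 35.2 percentage points lower from compound 1 to compound 4 (beyond the scatter). On the core of compound 1, then, chloro does not stand in for hydroxy at this position, and the inhibition seen with hydroxy is largely lost once that group, with its hydrogen-bond donor and acceptor, is gone. Nothing available here explains this loss.

Whether hydroxy itself is needed stays open, as chloro is the only replacement shown, and a methoxy group or an amine at the same place could behave differently. Also open, on these data alone, is whether hydroxy would count for as much with a carboxylic acid in place of the fluoro.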